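Nitro for hydroxy at the aromatic carbon of compound 3

The source may hold more compounds than are shown below. What is called first, only, known or untested is meant among the compounds shown, and "the series" means these compounds.

Of the compounds shown here, three have been measured in a functional assay on K562 cells (Homo sapiens) for antiproliferative activity, read by MTT assay, with a stated time of 48 h; a lower number here means a stronger inhibitor, a higher number a weaker inhibitor. Compound 1 `CN(C)C(=O)N(Cc1cccc([N+](=O)[O-])c1)Cc1ccco1` gives 35400 nM. Compound 2 `CCOC(=O)N1CCC(N(Cc2cc(Cl)ccc2O)C(=O)N(C)C)CC1` gives 38400 nM. Compound 3 `CN(C)C(=O)N(Cc1ccc(O)cc1)Cc1ccco1` gives 18600 nM, the lowest of the three numbers; its gap to compound 1 lies within the usual scatter, while its gap to compound 2 lies beyond it.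

Compound 4 `CN(C)C(=O)N(Cc1ccc([N+](=O)[O-])cc1)Cc1ccco1` has not yet been measured. It differs from compound 3 in one place: nitro in place of hydroxy on an aromatic carbon. Going by the values given here, no step between measured compounds shows this exact change on its own, though compound 1 also carries a nitro group and a dimethylurea and sits close to compound 3 within the scatter. On that ground the change is expected to move the number little, if at all, in this assay, perhaps slightly upward. Compound 4 is therefore estimated at 28000 nM, with a range from 10000 nM to 80000 nM, an expected step of a 1.5-fold higher number from compound 3 to compound 4 (0.18 log units; within the scatter).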

Compound 4, half-maximal inhibitory concentration: 35400 nM
Compound 4: middle estimate off by 1.3-fold (0.10 log units), on the low side; low and high end bracket the measured number.
By their numbers in this assay, from the lowest: compounds 3, 1, 4 and 2 (each within the scatter of the next, the first and the last beyond it).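

In this assay the exchange of hydroxy for nitro on an aromatic carbon, para to a large group, gives a 1.9-fold higher number from compound 3 to compound 4 (0.28 log units; within the scatter) and so stays within the scatter, even though the hydrogen-bond donor of compound 3 leaves and the nitro brings more heavy atoms. This position therefore accepts two quite different groups without a clear shift in the number. Compound 4 also prints the same number as its counterpart with the nitro elsewhere on the ring, compound 1 at 35400 nM in this assay. No measurement at hand offers an explanation for these numbers.

On these data alone, whether an amine, a carboxylic acid or a methoxy group at this position would move the number beyond the scatter remains open. So does whether the same exchange would behave alike on a core without the furan.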